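A few compounds are considered here, and "the series" means these few. Any claim that something is new, unique, unknown or untested is made for them only; others in the source may bear on it.

Measured so far:
compound 1 `O=C(CN(c1nc(Cl)nc2[nH]cnc12)C1CC1)N[C@@H](CO)C(=O)OCc1ccccc1` — 34.2%
compound 2 `N=C(N)NCCC[C@H](NC(=O)CN(c1nc(Cl)nc2[nH]cnc12)C1CC1)C(=O)O` — 51%

In a functional assay on the whole organism (Tail, strain ICR) with Mus musculus as the target, in the tail flick test, with a stated time of 60 min, at a dose of 25 umol/kg by the oral route (on this read-out higher numbers stand for a stronger effect at the one dose given and lower numbers for a weaker effect), compound 1 gives 34.2%, the lowest of the two numbers. Compound 2 gives 51%, which lies higher by more than the scatter. Compound 3 `C[C@@H](O)[C@H](NC(=O)CN(c1nc(Cl)nc2[nH]cnc12)C1CC1)C(=O)OCc1ccccc1` differs from compound 1 by methyl in place of hydrogen on a saturated chain carbon bound to an oxygen on a saturated carbon and a saturated chain carbon. Among the compounds with values here, no step of this kind between measured compounds is at hand, so no measured precedent guides the direction. Given that a single methyl enters, the step is expected to stay within the scatter, with a small rise or fall equally possible. Compound 3 is therefore expected to give 37%, between 22% and 54%. This expectation amounts to a step of a number 2.8 percentage points higher from compound 1 to compound 3 (within the scatter), estimated to lie within the scatter.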

Compound 3, a percentage reported as activity, at one dose (the size of the read-out at that dose, not a potency): 29.7%
Compound 3: the middle estimate sits 7.3 percentage points above what was measured; low and high end bracket the measured number.
By their numbers in this assay, from the lowest: compounds 3 and 1 (each within the scatter of the next); then compound 2.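

Replacing hydroxymethyl with 1-hydroxyethyl gives, in this assay, a number 4.5 percentage points lower from compound 1 to compound 3 (within the scatter), the first step read at this position. On a saturated chain carbon bound to an oxygen on a saturated carbon and a saturated chain carbon, a single added methyl therefore does not separate the two compounds at this one dose. No measurement here offers a reason for this result. On these data alone, it remains open how a longer chain, such as ethyl or propyl, would read on this carbon, and how an amine in place of the hydroxyl would read.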